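The source may hold more compounds than are shown below. What is called first, only, known or untested is meant among the compounds shown, and "the series" means these compounds.

Measured so far:
compound 1, `COc1cc(C2=NN(C(C)=O)C(c3cc(Cl)cc(Cl)c3)O2)cc(OC)c1OC`: 6.6%
compound 2, `COc1cc(C(=O)N/N=C/c2ccccc2F)cc(OC)c1OC`: 76.5%

In a functional assay on BGC-823 cells (Homo sapiens) for antiproliferative activity, read by MTT assay, tested at 5 uM (on this read-out lower numbers stand for a weaker effect and higher numbers for a stronger effect at the one concentration tested), compound 1 gives 6.6%, the lowest of the two numbers; the nearest is compound 2, whose value sits far enough above it to fall beyond the usual scatter. Compound 3, `COc1cc(C2=NN(C(C)=O)C(c3cccc(F)c3)O2)cc(OC)c1OC`, has not been measured in this assay yet. It differs from compound 1 in one place: 3-fluorophenyl in place of 3,5-dichlorophenyl on a saturated ring carbon. Going by the values given here, with no measured step of this kind available, only a small change is expected, if any at all: the step of a number 3.4 percentage points higher from compound 1 to compound 3 (within the scatter) is estimated to stay within the scatter. Compound 3 is therefore expected to give about 10%, somewhere between 0% and 30%.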

Compound 3, a percentage reported as inhibition, at one concentration (the size of the read-out at that concentration, not a potency): 37.7%
Compound 3: the middle estimate sits 27.7 percentage points below what was measured, outside the stated range (above it).
By their numbers in this assay, from the lowest: compound 1; then compound 3; then compound 2.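

In this assay, the group on the saturated ring carbon clearly affects the result: 3-fluorophenyl in place of 3,5-dichlorophenyl brings a number 31.1 percentage points higher from compound 1 to compound 3 (beyond the scatter) with the rest of the molecule left as it was. This one exchange shows that this position can move the read-out well beyond ordinary scatter. No available evidence explains the rise.

As far as these compounds go, it remains open whether removing the two chlorines or adding the fluorine matters more, which 3-chlorophenyl or plain phenyl could help separate. From the compounds shown here alone, how an amine or a carboxylic acid on this phenyl ring would behave also remains open.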